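Working notes: methylsulfonyl on the hydroxy oxygen of compound 2

This account rests on a few compounds, and the source may have more. Where it says the series, first, only, none or still open, it means among the compounds named here.

Measured in an ADME assay on HEp-2 cells (Homo sapiens) for cytotoxicity, read by MTT assay, with a stated time of 60 h; a higher number here means that more compound is tolerated, a lower number that less compound is tolerated:
- compound 1 `Cc1ccc(S(=O)(=O)O[C@@H]2CO[C@H]3[C@@H]2OCc2nc4cc(Br)c(Br)cc4n23)cc1`: 87500 nM
- compound 2 `O[C@@H]1CO[C@H]2[C@@H]1OCc1nc3cc(Br)c(Br)cc3n12`: 181000 nM

Of the two measured compounds, compound 2 stands highest at 181000 nM. Compound 1 lies lower at 87500 nM, and that gap is beyond the scatter.

The next compound to be measured is compound 3 `CS(=O)(=O)O[C@@H]1CO[C@H]2[C@@H]1OCc1nc3cc(Br)c(Br)cc3n12`. Its difference from compound 2 is methylsulfonyl in place of hydrogen on an oxygen on a saturated carbon. In words, methylsulfonyl sits in place of hydrogen on an oxygen on a saturated carbon, so hydroxy becomes (methylsulfonyl)oxy.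

Going by the values given here, no measured step in this assay covers this change, so the expectation has little support. Among the compounds with values here, it leans on compound 1 at 87500 nM, the only other number, and points to a lower number than that of compound 2. The expected change is a 1.6-fold lower number from compound 2 to compound 3 (0.22 log units; within the scatter), a modest step downward that would stay within the scatter. For compound 3 the estimated value is 110000 nM, with an expected range of 50000 nM to 210000 nM.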

Compound 3, half-maximal cytotoxic concentration: 99500 nM
Estimate against measurement, compound 3: 1.1-fold (0.04 log units) above; the measured number falls inside the stated range.
By their numbers in this assay, from the lowest: compounds 1, 3 and 2 (each within the scatter of the next, the first and the last beyond it).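

In this assay the hydroxy oxygen of the series now has its first readable step: methylsulfonyl in place of hydrogen on this oxygen gives a 1.8-fold lower number from compound 2 to compound 3 (0.26 log units; within the scatter) and so does not separate the two compounds. On the sulfonyl sulfur, methyl in place of 4-methylphenyl gives a 1.1-fold higher number from compound 1 to compound 3 (0.06 log units; within the scatter) and so leaves these two compounds together as well. Compound 3 therefore sits within the scatter of both neighbours, while only compound 1 and compound 2, the two ends of the order, stand apart beyond the scatter, and no measurement shown here accounts for any of these numbers.

Going by these compounds, with so few compounds, it remains open whether the gap between the two ends reflects the sulfonyl ester as such or only adds up from two small steps that each stay within the scatter. Also open, on these data alone, is how an amine or a carboxylic acid in place of the hydroxy would read in this assay and whether a longer chain on the sulfonyl sulfur would stay with compound 1 and compound 3.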